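From piperidin-4-yl to piperidin-3-yl on the carbonyl carbon

The source may report more compounds than this note shows. Statements on the series, on what has been measured and on what is new or still open speak of the compounds shown alone.

In a functional assay on the whole organism with Mus musculus as the target (on this read-out higher numbers stand for an effect only at larger amounts of compound and lower numbers for an effect already at smaller amounts), compound 1 (`C=CC(N)CCC(=O)N1CCCC(C(=O)OC)C1`) gives 150 umol/kg as a measured number. Compound 2 (`C=CC(CCC(=O)OC)NC(=O)C1CCNCC1`) gives > 540 umol/kg in this assay as a limit of the assay and not a number. Compound 3 (`C=CC(CCC(=O)OC)NC(=O)C1CCCNC1`) has piperidin-3-yl in place of piperidin-4-yl on a carbonyl carbon. Among the compounds with values here, no measured step covers this change. The expected change runs towards smaller doses, with an at least 1.8-fold lower number from compound 2 to compound 3 (0.25 log units; that floor lies within the scatter) as the estimate, and a result at the limit remains possible. This expectation rests only on compound 1 at 150 umol/kg and remains tentative. Compound 3 is estimated at 300 umol/kg with a range of 100 umol/kg to 800 umol/kg expected.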

Compound 3, dose for half-maximal effect: 410 umol/kg
The estimate for compound 3 lay 1.4-fold (0.14 log units) below the measured number, within the range that was stated.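

In this assay, piperidin-3-yl on the carbonyl carbon gives compound 3 a measured number, whereas piperidin-4-yl leaves compound 2 with only a limit of the assay. The step is an at least 1.3-fold lower number from compound 2 to compound 3 (0.11 log units; that floor lies within the scatter), so a difference beyond the scatter is neither shown nor excluded. Its true size stays unknown because compound 2 gives only a limit: the limit of > 540 umol/kg in this assay, at which 1 of the 3 values shown sits.

Open, on these data alone, is how the read-out responds to piperidin-2-yl or pyrrolidin-3-yl on the same carbonyl carbon. Also open, as far as these compounds go, is the effect of a methyl group on the nitrogen of piperidin-3-yl.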